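Series notes: chloro in place of hydroxymethyl

This account rests on a few compounds, and the source may have more. Where it says the series, first, only, none or still open, it means among the compounds named here.

Measured so far:
- compound 1, `Fc1cccc(-c2csc(=S)[nH]2)c1`, gives 28% in an assay on isolated protein for inhibition of Indoleamine 2,3-dioxygenase 1 (Homo sapiens), read by colorimetric assay, with stated times of 10 min and 30 min, tested at 100 uM; on this read-out higher numbers stand for more inhibition at the one concentration tested (going by the name of the read-out) and lower numbers for less inhibition
- compound 2, `OCc1cccc(-c2csc(=S)[nH]2)c1`, gives 16% in this assay

For the measured compounds named here, compound 2 stands lowest of the two numbers; the only measured step is a number 12 percentage points lower from compound 1 to compound 2 (beyond the scatter), beyond the scatter. Compound 3, `S=c1[nH]c(-c2cccc(Cl)c2)cs1`, differs from compound 2 by chloro in place of hydroxymethyl on an aromatic carbon. The step from compound 1 to compound 2 bears on this change, since the hydroxymethyl that entered there now leaves, and a halogen returns; a rise of comparable size is therefore expected, namely a number 14 percentage points higher from compound 2 to compound 3 (beyond the scatter). For compound 3 the estimated value in this assay is 30%, with a range from 15% to 45%.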

Compound 3, a percentage reported as inhibition, at one concentration (the size of the read-out at that concentration, not a potency): 40%
Beside the measured number, compound 3's estimate is 10 percentage points below it, and the stated range covers the measured number.
By their numbers in this assay, from the lowest: compound 2; then compound 1; then compound 3.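

In this assay chloro in place of hydroxymethyl gives a number 24 percentage points higher from compound 2 to compound 3 (beyond the scatter) and so places compound 3 highest of the three. Chloro in place of fluoro gives a number 12 percentage points higher from compound 1 to compound 3 (beyond the scatter) and shows for the first time that the two halogens at this place are not interchangeable. Nothing at hand explains either step.

From the compounds shown here alone, whether bromo or trifluoromethyl would extend the rise from fluoro to chloro remains open. Also open, going by these compounds, is how an amine or a carboxylic acid on this aromatic carbon would compare with hydroxymethyl.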